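The compounds below may be only part of what the source reports. "The series", "measured", "known", "first", "only" and "open" are said of these compounds alone.

Measured in a functional assay on a cell-free system (Platelet, plasma, Homo sapiens) for inhibition; on this read-out lower numbers stand for stronger inhibition and higher numbers for weaker inhibition:

- compound 1 `CCCCCCOc1cccc(NC(=O)C2CCCNC2)c1`: 113000 nM
- compound 2 `O=C(Nc1cccc(OCc2ccc(-c3ccccc3)cc2)c1)C1CCCNC1`: 153000 nM
- compound 3 `O=C(Nc1cccc(OCc2ccc(-c3ccccc3)cc2)c1)C1CCNCC1`: 111000 nM

In this assay compound 3 stands at 111000 nM, within the scatter of both compound 1 and compound 2, so no order can be read among them.

The next compound keeps everything in compound 3 except one ring. Compound 4 `O=C(Nc1cccc(OCc2ccc(-c3cc(F)cc(F)c3)cc2)c1)C1CCNCC1` has 3,5-difluorophenyl in place of phenyl on an aromatic carbon.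

Among the measured compounds shown here, only one measured step links two compounds differing in a single place. This is a 1.4-fold lower number from compound 2 to compound 3 (0.14 log units; within the scatter), where piperidin-4-yl replaces piperidin-3-yl. That step is small and concerns a different part of the molecule. For the measured compounds named here, no measured compound carries fluorine, so the data give no direct guide to this change. With nothing pointing either way, no shift beyond the scatter is expected in this assay.

The expected step is a 1.1-fold lower number from compound 3 to compound 4 (0.05 log units; within the scatter), an estimate with no firm direction.

For compound 4 the estimated value is 100000 nM, with an expected range from 45000 nM to 200000 nM.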

Compound 4, half-maximal inhibitory concentration: 27800 nM
Beside the measured number, compound 4's estimate is 3.6-fold (0.56 log units) above it; the measured number lies below the stated range.
By their numbers in this assay, from the lowest: compound 4; then compounds 3, 1 and 2 (each within the scatter of the next).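

In this assay, among the compounds shown here, replacing phenyl with 3,5-difluorophenyl gives a 4.0-fold lower number from compound 3 to compound 4 (0.60 log units; beyond the scatter), the first step in this set that lies beyond the scatter. For the compounds shown here, the only earlier step between compounds differing in one place, a 1.4-fold lower number from compound 2 to compound 3 (0.14 log units; within the scatter), concerned the piperidine attachment and could not show any response to structure; this one shows that the number does respond to a change in the ring at the end of the biphenyl-like arm, on the aromatic carbon para to a large group. No measurement shown here explains why the two fluorines have this effect.

As far as these compounds go, it remains open whether a single fluorine would give a similar step, or whether chlorine atoms or methyl groups in the same places would do so. From the compounds shown here alone, it is equally open whether the same change would carry over to the piperidin-3-yl series of compound 2.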